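A few compounds are considered here, and "the series" means these few. Any claim that something is new, unique, unknown or untested is made for them only; others in the source may bear on it.

Compounds measured so far:
compound 1, `Nc1ccccc1NC(=O)/C=C/c1ccc(Cn2cnc3c(Nc4ccccc4)nc(Cl)nc32)cc1`, 16.4%
compound 2, `Nc1ccccc1NC(=O)c1ccc(Cn2cnc3c(Nc4ccc(-c5ccccn5)cc4)nc(Cl)nc32)cc1`, 11.5%
compound 3, `Nc1ccccc1NC(=O)c1ccc(Cn2cnc3c(Nc4cccc(OC(F)(F)F)c4)nc(Cl)nc32)cc1`, 1.88%

These three were tested in a functional assay on HepG2 cells (Homo sapiens) for antiproliferative activity, read by CCK-8 assay, with a stated time of 72 h, tested at 2 uM; a higher number here means a stronger effect of the compound at the concentration tested, a lower number a weaker effect. Compound 3 gives the lowest of the three numbers: compound 2 lies nearer, and the step of a number 9.6 percentage points lower from compound 2 to compound 3 (within the scatter) is within the scatter, while compound 1 lies further off, beyond the scatter. Compound 4, `CC1CCN(c2nc(Cl)nc3c2ncn3Cc2ccc(C(=O)Nc3ccccc3N)cc2)CC1`, has not yet been measured. It differs from compound 3 in one place: 4-methylpiperidin-1-yl in place of (3-(trifluoromethoxy)phenyl)amino on an aromatic carbon. Going by the values given here, only one measured step touches the same aromatic carbon, namely a number 9.6 percentage points lower from compound 2 to compound 3 (within the scatter), and it is within the scatter. No measured step exchanges an amino substituent there for a saturated ring, so no shown step bears directly on this change. The expectation for compound 4 therefore rests on compound 3 alone, and no step beyond the scatter is expected in this assay. The estimate for compound 4 is 6%, between 0% and 18%, which is expected to mean a step of a number 4.1 percentage points higher from compound 3 to compound 4 (within the scatter).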

Compound 4, a percentage reported as inhibition, at one concentration (the size of the read-out at that concentration, not a potency): 1.22%
Compound 4: middle estimate off by 4.8 percentage points, on the high side, and the stated range covers the measured number.
By their numbers in this assay, from the lowest: compounds 4, 3, 2 and 1 (each within the scatter of the next, the first and the last beyond it).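

In this assay, putting 4-methylpiperidin-1-yl in place of (3-(trifluoromethoxy)phenyl)amino on the aromatic carbon next to the ring nitrogen gives a number 0.7 percentage points lower from compound 3 to compound 4 (within the scatter). This is the first step shown at this position that replaces an aryl amino group with a saturated ring, and the entering group, with 7 heavy atoms and 0 hydrogen-bond donors, leaves the number in the same range as the leaving group, although compound 3 already gives only 1.88%, so the read-out has little room to show any further loss. Nothing available explains this result.

The compounds shown leave open whether a morpholine ring or a dimethylamino group on this carbon would move the number beyond the scatter. They also leave open what an amine in place of the chloro group on the same ring would do.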